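From Compound 2 to Its Hydroxy Analogue, Compound 3

The compounds below may be only part of what the source reports. "The series", "measured", "known", "first", "only" and "open" are said of these compounds alone.

In a functional assay, read by fluorescence and spectrophotometry, with a stated time of 1 h (on this read-out higher numbers stand for an effect only at larger amounts of compound and lower numbers for an effect already at smaller amounts), compound 2 `CCCCCCCCCS(=O)(=O)/C=C/c1ccc(O)c(O)c1` gives 7700 nM and compound 1 `C=CCCCCCCS(=O)(=O)/C=C/c1ccc(O)c(O)c1` gives 6400 nM, so the two stand level within the scatter. Compound 3 `O=S(=O)(/C=C/c1ccc(O)c(O)c1)CCCCCCCCCO` differs from compound 2 by hydroxy in place of hydrogen on a saturated chain carbon, nine bonds along the chain from a sulfonyl sulfur. Among the compounds with values here, the only measured step, a 1.2-fold higher number from compound 1 to compound 2 (0.08 log units; within the scatter), puts propyl in place of vinyl and involves no hydroxy, so it offers weak guidance and no direction. No change beyond the scatter is therefore expected, and the estimated step is a 1.2-fold higher number from compound 2 to compound 3 (0.07 log units; within the scatter). For compound 3 the estimated value is 9000 nM, with an expected range of 3000 nM to 25000 nM.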

Compound 3, half-maximal effective concentration: 7500 nM
The estimate for compound 3 lay 1.2-fold (0.08 log units) above the measured number; the measured number falls inside the stated range.
By their numbers in this assay, from the lowest: compounds 1, 3 and 2 (each within the scatter of the next).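

In this assay, the two stand level when hydroxy takes the place of hydrogen on the saturated chain carbon nine bonds along the chain from the sulfonyl sulfur (a 1.0-fold lower number from compound 2 to compound 3 (0.01 log units; within the scatter)). Within the data shown here, the same holds for 3-hydroxypropyl in place of vinyl (a 1.2-fold higher number from compound 1 to compound 3 (0.07 log units; within the scatter)), so this position, until now seen only with hydrocarbon groups, also takes a hydroxy without a step beyond the scatter. No evidence is available that bears on this result. On these data alone, whether an amine, a carboxylic acid or a longer chain would also stand level remains open. So does whether any group here moves the number beyond the scatter at all.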